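The source may hold more compounds than are shown below. What is called first, only, known or untested is meant among the compounds shown, and "the series" means these compounds.

In a functional assay (aorta) for inhibition, with Rattus norvegicus as the target (a lower number here means a stronger inhibitor, a higher number a weaker inhibitor), compound 1 `[O-][S+]1CCCC[C@@H]1c1cccnc1` reads > 30000 nM, which is a limit of the assay and not a number. Compound 2 `C/N=C(\S)[C@]1(c2ccccc2)CCCC[S+]1[O-]` gives 9500 nM. Compound 3 `CCC/N=C(\S)[C@]1(c2cccnc2)CCCC[S+]1[O-]` gives 600 nM, the lower of the two actual numbers, and its gap to compound 2 lies beyond the usual scatter. Compound 4 `CCCC/N=C(\S)[C@]1(c2cccnc2)CCCC[S+]1[O-]` differs from compound 3 in one place: methyl in place of hydrogen on a saturated chain carbon, three bonds along the chain from a double-bonded nitrogen. This puts methyl in place of hydrogen on a saturated chain carbon, three bonds along the chain from a double-bonded nitrogen, turning propyl into butyl. Among the compounds with values here, no measured pair shows this change, so in this assay only a small step is expected, within the scatter and in no firm direction. The estimated step is a 1.2-fold higher number from compound 3 to compound 4 (0.07 log units; within the scatter). For compound 4 the estimated value is 700 nM, with an expected range from 200 nM to 2500 nM.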

Compound 4, concentration for 90% inhibition: 8000 nM
The estimate for compound 4 lay 11-fold (1.06 log units) below the measured number; the whole stated range lies below it.
By their numbers in this assay, from the lowest: compound 3; then compounds 4 and 2 (each within the scatter of the next). At a limit, above all of these: compound 1.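

Lengthening the chain from propyl to butyl gives a 13-fold higher number from compound 3 to compound 4 (1.12 log units; beyond the scatter) in this assay. Within the data shown here, this is the first pair here that differs in one place, and it shows that this chain position is sensitive: a single added methyl is enough for a large loss of inhibition. Nothing measured here gives a reason for this loss.

As far as these compounds go, whether the trend continues with a longer chain such as pentyl remains open. So does the effect of ending the propyl chain in an amine or a carboxylic acid.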